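Swapping a propargyl for a 4-chlorobenzyl group

The source may report more compounds than this note shows. Statements on the series, on what has been measured and on what is new or still open speak of the compounds shown alone.

Compound 1 `C#CCOC(c1cccs1)c1cc2ccccc2nc1Cl` gives > 100000 nM
Compound 2 `Cc1ccc(-c2cc(COC(c3cccs3)c3cc4ccccc4nc3Cl)on2)cc1` gives "not active" (no number reported)
Compound 3 `Oc1ccc(-c2cc(COC(c3cccs3)c3cc4ccccc4nc3Cl)on2)cc1` gives "not active" (no number reported)

In a functional assay on MCF7 cells (Homo sapiens) for inhibition, read by WST assay, with stated times of 72 h and 2 h (on this read-out higher numbers stand for weaker inhibition and lower numbers for stronger inhibition), compound 1 gives a limit and not a number (> 100000 nM). The only figure for this series is therefore the limit of > 100000 nM in this assay, at which 1 of the 3 values shown sits, and no exact potency is known for compound 1. Compound 2 ("not active" (no number reported)) and compound 3 ("not active" (no number reported)) come without any number at all.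

Compound 4 `Clc1ccc(COC(c2cccs2)c2cc3ccccc3nc2Cl)cc1` has not yet been measured. It keeps the core of compound 1 and differs from it by one change (4-chlorophenyl in place of ethynyl on a saturated chain carbon bound to an oxygen on a saturated carbon). In words, this is 4-chlorophenyl in place of ethynyl on a saturated chain carbon bound to an oxygen on a saturated carbon, or propargyl to 4-chlorobenzyl when cut one bond further out.

Among the compounds with values here, no measured pair here differs in a single place, so no step can be read directly from the data. With none of the three measured compounds giving an exact number, only a modest gain in inhibition is expected in this assay, and another limit would be no surprise. The estimate amounts to an at least 2.0-fold lower number from compound 1 to compound 4 (0.30 log units; that floor lies within the scatter) and is read against a limit. Compound 4 is expected at 50000 nM with an estimated range from 10000 nM to 150000 nM as its likely span.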

Compound 4, half-maximal inhibitory concentration: 28300 nM
For compound 4 the middle estimate is 1.8-fold (0.25 log units) above the measured one, and the stated range covers the measured number.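

Putting 4-chlorophenyl in place of ethynyl on a saturated chain carbon bound to an oxygen on a saturated carbon gives, in this assay, an at least 3.5-fold lower number from compound 1 to compound 4 (0.54 log units; beyond the scatter). Within the data shown here, compound 4 provides the first exact number, at 28300 nM, which shows that the group at this place can change the read-out while the core of compound 1 stays the same. The full size of the step remains unknown, because compound 1 has only a limit and not an exact number: the limit of > 100000 nM in this assay, at which 1 of the 4 values shown sits.

The compounds shown leave open whether the gain belongs to the aromatic ring or to its chlorine, a question that a plain benzyl group without chlorine could help to answer, and whether a benzyl group carrying an amine or a carboxylic acid would fit this place as well. Among these compounds, compound 2 and compound 3 carry no number, so no step involving them can be read, and how their larger groups compare with the 4-chlorobenzyl group of compound 4 stays unanswered.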